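Removing the Nitro Group: Solubility of Compound 4

This account rests on a few compounds, and the source may have more. Where it says the series, first, only, none or still open, it means among the compounds named here.

Measured compounds:
compound 1 `O=[N+]([O-])c1ccc(-c2ccc(O[C@H]3O[C@H](CO)[C@@H](O)[C@H](O)[C@@H]3O)c(Cl)c2)cc1` — 117 ug/mL
compound 2 `Cc1cccc(-c2ccc(O[C@H]3O[C@H](CO)[C@@H](O)[C@H](O)[C@@H]3O)c(Cl)c2)c1` — 7.1 ug/mL
compound 3 `OC[C@H]1O[C@H](Oc2ccc(-c3ccc(Cl)c(C(F)(F)F)c3)cc2Cl)[C@@H](O)[C@@H](O)[C@@H]1O` — 1 ug/mL

Of the compounds shown here, three sharing the same core have been measured in a physicochemical assay for solubility, measured as kinetic solubility, with a stated time of 15 h, at pH 7.4; on this read-out lower numbers stand for lower solubility and higher numbers for higher solubility. Compound 1 gives the highest number of the three, 117 ug/mL. Compound 2 comes next with 7.1 ug/mL, and compound 3 sits furthest away at 1 ug/mL. For the measured compounds named here, the one single-point step that has been measured, a 16-fold lower number from compound 1 to compound 2 (1.22 log units; beyond the scatter), shows that exchanging the 4-nitrophenyl on compound 1 for another aryl group costs a great deal in this assay.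

Compound 4 `OC[C@H]1O[C@H](Oc2ccc(-c3ccccc3)cc2Cl)[C@@H](O)[C@@H](O)[C@@H]1O` is the unmeasured member. It differs from compound 1 in one place: hydrogen in place of nitro on an aromatic carbon. The measured step from compound 1 to compound 2 bears on this most directly, since in both cases the nitro leaves the same position, but the 3-methylphenyl of compound 2 is not the plain phenyl of compound 4. Compound 4 is therefore expected to fall clearly below compound 1, with a step of a 7.8-fold lower number from compound 1 to compound 4 (0.89 log units; beyond the scatter) that is beyond the scatter, and to land somewhat above compound 2. The estimate for compound 4 in this assay is 15 ug/mL, with a range from 4 ug/mL to 50 ug/mL.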

Compound 4, solubility: 5.5 ug/mL
Compound 4: middle estimate off by 2.7-fold (0.44 log units), on the high side, and the stated range covers the measured number.
By their numbers in this assay, from the lowest: compound 3; then compounds 4 and 2 (each within the scatter of the next); then compound 1.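

With hydrogen in place of nitro on the aromatic carbon para to a large group, and nothing else altered, this assay shows a clean single-change step of a 21-fold lower number from compound 1 to compound 4 (1.33 log units; beyond the scatter). This isolates the nitro at this position, which the earlier step could not do, since that step also brought in a methyl at a different place on the ring. The second new step, a 1.3-fold lower number from compound 2 to compound 4 (0.11 log units; within the scatter), shows that this read-out does not separate the 3-methylphenyl from the phenyl, so the large drop seen earlier is matched by the loss of the nitro alone, and the methyl adds nothing that can be read beyond the scatter. No measurement at hand explains why the nitro compound stands so far apart from the other two.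

From the compounds shown here alone, it remains open whether the high number is particular to the nitro or would also appear with another group on the same carbon, such as a nitrile, a carboxylic acid or an amine. Going by these compounds, it is equally open whether a nitro on a different carbon of that ring would keep the number seen for compound 1.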